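Series notes: five-membered ring swap on the shared core

This account rests on a few compounds, and the source may have more. Where it says the series, first, only, none or still open, it means among the compounds named here.

Of the compounds shown here, two have been measured in an ADME assay on microsomes from liver (Rattus norvegicus) for metabolic stability, read by LC-MS; on this read-out lower numbers stand for slow clearance and higher numbers for fast clearance. Compound 1 `COc1cc(N2CCN(C(=O)N[C@@H](C)c3cccc4ccccc34)CC2)ccc1-n1cnc(C)n1` gives 110 mL.min-1.g-1 in this assay. For the measured compounds named here, compound 2 `COc1cc(N2CCN(C(=O)NCc3cccc4ccccc34)CC2)ccc1-c1cnc(C)o1` gives 160 mL.min-1.g-1 in this assay; the two numbers lie within the usual scatter of one another, so no order between compound 1 and compound 2 can be read from them, and they differ in more than one place, so no single step is defined.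

Compound 3 `COc1cc(N2CCN(C(=O)N[C@@H](C)c3cccc4ccccc34)CC2)ccc1-c1cnn(C)c1` is not yet measured. It differs from compound 1 by 1-methyl-1H-pyrazol-4-yl in place of 3-methyl-1H-1,2,4-triazol-1-yl on an aromatic carbon. Going by the values given here, no measured pair shows the effect of such a ring swap in this assay, so there is no basis for expecting a step beyond the scatter in either direction. For compound 3 the expected value in this assay is therefore 130 mL.min-1.g-1, within a range of 60 mL.min-1.g-1 to 280 mL.min-1.g-1, corresponding to an expected step from compound 1 to compound 3 of a 1.2-fold higher number from compound 1 to compound 3 (0.07 log units; within the scatter).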

Compound 3, intrinsic clearance in microsomes: 150 mL.min-1.g-1
For compound 3 the middle estimate is 1.2-fold (0.06 log units) below the measured one; the range from low to high includes it.
By their numbers in this assay, from the lowest: compounds 1, 3 and 2 (each within the scatter of the next).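

At the place para to a large group and ortho to a methoxy group, the series now has its first single-place comparison in this assay: 1-methyl-1H-pyrazol-4-yl in place of 3-methyl-1H-1,2,4-triazol-1-yl gives a 1.4-fold higher number from compound 1 to compound 3 (0.13 log units; within the scatter). For the compounds shown here, this exchange of one five-membered aromatic ring for another, going from 3 hetero atoms to 2, therefore produces no step that can be told from the scatter on this read-out. Nothing further is available to account for the result.

Still open, on these data alone, is whether a group of another kind at this place, such as a dimethylamino group or a carboxylic acid, would give a step beyond the scatter. Compound 2 differs from compound 1 and compound 3 in more than one place, so the contribution of each of its differences remains unresolved.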